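The source may hold more compounds than are shown below. What is called first, only, known or untested is meant among the compounds shown, and "the series" means these compounds.

In a functional assay on Jurkat cells (Homo sapiens) for cytotoxicity, with a stated time of 72 h (a higher number here means that more compound is needed for the effect, a lower number that less compound is needed), compound 1 `C=C[C@@](C)(/C=C/c1ccc(O)cc1)CC/C=C(\C)C(=O)OCC` gives > 49000 nM, which is a limit of the assay and not a number. Compound 2 `C=C[C@@](C)(/C=C/c1ccc(O)c(/C=C/c2ccc(F)cc2)c1)CCC=C(C)C` gives > 49000 nM, again a limit. Compound 3 `COc1ccc(/C=C/[C@@](C)(/C=C/c2ccc(O)c(C=O)c2)CCC=C(C)C)cc1` gives > 49000 nM, also a limit. The whole set therefore reads (the limit of > 49000 nM in this assay, at which 3 of the 3 values shown sit). Compound 3 has no exact value, and the data cannot rank it against compound 1 or compound 2.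

Compound 4 `CCOC(=O)/C(C)=C/c1cc(/C=C/[C@](C)(/C=C/c2ccc(OC)cc2)CCC=C(C)C)ccc1O` comes from compound 3 through a single change, 2-(ethoxycarbonyl)prop-1-en-1-yl in place of formyl on an aromatic carbon, ortho to a hydroxy group. For the measured compounds named here, the entering group is clearly the larger of the two, but no measured pair shows what a swap of this kind does in the assay. The expectation must therefore rest on the three limits alone, and none of them gives a starting number. With compound 3 recorded only as > 49000 nM, the most cautious forecast is little or no movement, with any shift going towards less compound being needed. The expected change is an at least 1.4-fold lower number from compound 3 to compound 4 (0.14 log units; that floor lies within the scatter), and another result at the same limit would be quite likely. For compound 4 the estimate is 35000 nM, with an expected range from 12000 nM to 49000 nM.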

Compound 4, half-maximal effective concentration: > 49000 nM
Compound 4: a limit, no number; the forecaster's own chance of this, stated with the estimate: 65%; middle value at least 1.4-fold (0.14 log units) away from the limit.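

Compound 3 and compound 4 are each recorded only as a limit of the assay and not as a number, so no step can be read between them. The compounds shown leave open where any of them would give an exact value in this assay, and therefore how they rank against one another: the limit of > 49000 nM in this assay, at which 4 of the 4 values shown sit.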